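Terminal amide nitrogen substituent change in pepsin inhibitors

A few compounds are considered here, and "the series" means these few. Any claim that something is new, unique, unknown or untested is made for them only; others in the source may bear on it.

In an assay on isolated protein for inhibition of Pepsin A (Sus scrofa) (a lower number here means a stronger inhibitor, a higher number a weaker inhibitor), compound 1 `CC(C)CCNC(=O)C(C)NC(=O)CCC(=O)[C@H](CC(C)C)NC(=O)C(NC(=O)CC(C)C)C(C)C` gives 2140 nM and compound 2 `CC(C)CCNC(=O)C(C)NC(=O)C(C)CC(=O)[C@H](CC(C)C)NC(=O)C(NC(=O)CC(C)C)C(C)C` gives 27 nM. Within the data shown here, the one step in hand, a 79-fold lower number from compound 1 to compound 2 (1.90 log units; beyond the scatter), is large; compound 2 therefore holds the lowest of the two numbers. Compound 3 `CC(C)CC(=O)NC(C(=O)N[C@@H](CC(C)C)C(=O)CC(C)C(=O)NC(C)C(=O)NC(=O)C(C)C)C(C)C` differs from compound 2 by isopropylcarbonyl in place of isopentyl on an amide-type nitrogen. Among the measured compounds shown here, no measured step touches this position, so the change from compound 2 to compound 3 has no precedent in this assay; a step of some size in either direction, or none beyond the scatter, is possible. Compound 3 is expected at 80 nM, within 15 nM to 400 nM, which as a step is estimated as a 3.0-fold higher number from compound 2 to compound 3 (0.47 log units; beyond the scatter).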

Compound 3, inhibition constant: 110 nM
Compound 3: middle estimate off by 1.4-fold (0.14 log units), on the low side; low and high end bracket the measured number.
By their numbers in this assay, from the lowest: compound 2; then compound 3; then compound 1.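

Among these compounds, this is the first reading at this position in this assay: a 4.1-fold higher number from compound 2 to compound 3 (0.61 log units; beyond the scatter) is a modest rise, so isopentyl on the amide-type nitrogen can give way to isopropylcarbonyl without a step as large as the one seen on the chain. The swap keeps the same heavy-atom count and adds one hydrogen-bond acceptor. Nothing measured bears on the origin of this step.

From the compounds shown here alone, whether an acetyl group or a longer chain on this nitrogen, or a carboxylic acid replacing the terminal amide, would do better remains open. Also open, going by these compounds, is whether the step holds on the core of compound 1.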